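A second chloro group on a weakly antiproliferative scaffold

The source may report more compounds than this note shows. Statements on the series, on what has been measured and on what is new or still open speak of the compounds shown alone.

Compound 2 `Cn1c(N2N=C(c3ccccc3)CC2c2ccccc2)nc(-c2ccc(Cl)cc2)c(C#N)c1=O` is the weaker of the two measured compounds. In a functional assay on MDA-MB-231 cells (Homo sapiens) for antiproliferative activity, with a stated time of 72 h (on this read-out lower numbers stand for stronger inhibition and higher numbers for weaker inhibition), compound 2 gives 29100 nM, whereas compound 1 `Cn1c(N2N=C(c3ccc(Cl)cc3)CC2c2ccccc2)nc(-c2ccccc2)c(C#N)c1=O` gives 10600 nM, a gap beyond the usual scatter. Compound 3 `Cn1c(N2N=C(c3ccc(Cl)cc3)CC2c2ccccc2)nc(-c2ccc(Cl)cc2)c(C#N)c1=O` is not yet measured; it differs from compound 2 by chloro in place of hydrogen on an aromatic carbon, para to a large group, so that a phenyl becomes a 4-chlorophenyl. For the measured compounds named here, no measured pair shows this exact change, so only a modest step toward a lower number is expected in this assay, namely a 1.9-fold lower number from compound 2 to compound 3 (0.29 log units; within the scatter). Compound 3 is accordingly estimated at 15000 nM, with a range from 5000 nM to 45000 nM.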

Compound 3, half-maximal inhibitory concentration: 12400 nM
Beside the measured number, compound 3's estimate is 1.2-fold (0.08 log units) above it; measured number inside the range.
By their numbers in this assay, from the lowest: compounds 1 and 3 (each within the scatter of the next); then compound 2.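

In this assay, chloro in place of hydrogen at this position gives a 2.3-fold lower number from compound 2 to compound 3 (0.37 log units; beyond the scatter), so this change counts here even with a chloro already on the other phenyl. The same change made at that other phenyl gives a 1.2-fold higher number from compound 1 to compound 3 (0.07 log units; within the scatter), so once this position carries chloro, the second chloro adds no readable difference. No measurement here explains this dependence on place. The compounds shown leave open how a methoxy group or an amine at this position would compare with chloro.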